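This account rests on a few compounds, and the source may have more. Where it says the series, first, only, none or still open, it means among the compounds named here.

Measured compounds:
- compound 1, `Cc1ccc(NC(=O)c2ccc(/N=N\c3c[nH]c4ccccc34)cc2)cc1`: 300 nM in a functional assay on P388 cells (Mus musculus) for inhibition, read by MTT assay, with a stated time of 72 h; a lower number here means a stronger inhibitor, a higher number a weaker inhibitor
- compound 2, `O=C(Nc1ccc([N+](=O)[O-])cc1)c1ccc(/N=N\c2c[nH]c3ccccc23)cc1`: compound 2 gives 11200 nM in this assay
- compound 3, `Cc1cccc(NC(=O)c2ccc(/N=N\c3c[nH]c4ccccc34)cc2)c1`: compound 3 gives 300 nM in this assay

Compound 1 and compound 3 differ only in 3-methylphenyl in place of 4-methylphenyl on an amide-type nitrogen; their numbers are level within the scatter, so nothing is read from that pair. Within the data shown here, the one step that matters is a 37-fold higher number from compound 1 to compound 2 (1.57 log units; beyond the scatter), carried by nitro in place of methyl on an aromatic carbon. The same kind of change leads from compound 3 to the unmeasured compound 4, `O=C(Nc1cccc([N+](=O)[O-])c1)c1ccc(/N=N\c2c[nH]c3ccccc23)cc1`, by nitro in place of methyl on an aromatic carbon; the two places differ in that the group sits para to a large group in the step from compound 1 to compound 2 and meta to a large group in the step from compound 3 to compound 4, so the earlier step is a guide rather than a copy. Among the measured compounds shown here, for compound 4 a step of about a 27-fold higher number from compound 3 to compound 4 (1.43 log units; beyond the scatter) is expected, resting on the single earlier step from compound 1 to compound 2 and, with less weight, on the pattern that the two methyl placements in compound 1 and compound 3 gave level numbers. Compound 4 is therefore estimated at 8000 nM, between 2000 nM and 30000 nM.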

Compound 4, half-maximal inhibitory concentration: 51900 nM
For compound 4 the middle estimate is 6.5-fold (0.81 log units) below the measured one; the whole stated range lies below it.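

Nitro in place of methyl gives a higher number in this assay on both cores, so the direction of the change carries across, but its size does not: the same change on two cores in this assay, a 37-fold higher number (1.57 log units; beyond the scatter) from compound 1 to compound 2 and a 170-fold higher number (2.24 log units; beyond the scatter) from compound 3 to compound 4, 4.6-fold (0.67 log units) apart, beyond the scatter of two such steps

The new step, a 170-fold higher number from compound 3 to compound 4 (2.24 log units; beyond the scatter), is the larger of the two, and moving the nitro group gives a 4.6-fold higher number from compound 2 to compound 4 (0.67 log units; beyond the scatter), whereas the two methyl placements in compound 1 and compound 3 stood level, so placement matters here with nitro but not with methyl. The step of a 170-fold higher number from compound 1 to compound 4 (2.24 log units; beyond the scatter) adds no separate evidence, and two pairs support carrying the change as a direction only, not as a fixed size, and they do not show what sets the size.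

On these data alone, it remains open whether an amine, a carboxylic acid or a methoxy group in the same places would follow methyl or nitro. As far as these compounds go, it is also open whether the dependence on placement seen with nitro would appear with any of these groups.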